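The compounds below may be only part of what the source reports. "The series", "measured", "known", "first", "only" and "open" are said of these compounds alone.

Of the compounds shown here, three have so far been tested in a functional assay on the whole organism (strain albino) for inhibition, with Rattus norvegicus as the target, read by paw edema, with stated times of 30 min and 2 h, at a dose of 100 mg/kg by the oral route; a lower number here means less inhibition, a higher number more inhibition at the dose given (going by the name of the read-out). Compound 1 `CC(Br)C(=O)Nc1ccc(C(=O)/C=C/c2ccc(Cl)cc2)cc1` gives 45%, compound 2 `CC(O[N+](=O)[O-])C(=O)Nc1ccc(C(=O)/C=C/c2ccco2)cc1` gives 48%, and compound 3 `O=C(COCc1c(-c2ccccc2)no[n+]1[O-])Nc1ccc(C(=O)/C=C/c2ccc(Cl)cc2)cc1` gives 48%. Compound 3 stands level with compound 2, and its gap to compound 1 lies within the usual scatter, so none of the three can be ranked against the others. Compound 4 `O=C(COCc1c(-c2ccccc2)no[n+]1[O-])Nc1ccc(C(=O)/C=C/c2ccco2)cc1` has not yet been measured; it differs from compound 3 by furan-2-yl in place of 4-chlorophenyl on a double-bonded chain carbon bound to a double-bonded chain carbon. Compound 1 carries the 4-chlorophenyl and compound 2 the furan-2-yl, and their values sit within the scatter of each other, so no step beyond the scatter is expected here either. Compound 4 is estimated at 48%, ranging from 38% to 58%. The expected step of no change at the digits printed from compound 3 to compound 4 (within the scatter) stays within the scatter.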

Compound 4, a percentage reported as inhibition, in the whole organism at one dose (the size of the read-out at that dose, not a potency): 45%
Compound 4: the middle estimate sits 3 percentage points above what was measured; the measured number falls inside the stated range.
By their numbers in this assay, from the lowest: compounds 1, 4, 2 and 3 (each within the scatter of the next).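

Furan-2-yl in place of 4-chlorophenyl on a double-bonded chain carbon bound to a double-bonded chain carbon gives a number 3 percentage points lower from compound 3 to compound 4 (within the scatter) in this assay. For the compounds shown here, compound 1 and compound 2 differ in more than one place, so this pair is the first clean comparison of the two groups, and in this read-out they cannot be told apart. No measurement shown here bears on this result.

As far as these compounds go, whether a cyclohexyl or a pyridyl group in this place would give a step beyond the scatter stays open, as does whether the two groups also match at other doses.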